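Series notes: bromo for nitro on the sulfonyl ring

The source may hold more compounds than are shown below. What is called first, only, known or untested is meant among the compounds shown, and "the series" means these compounds.

Compound 2 `N#CC1=C(NS(=O)(=O)c2ccc([N+](=O)[O-])cc2)N(c2ccc(S(N)(=O)=O)cc2)C2=C(C(=O)CCC2)C1c1ccc(Cl)cc1Cl` gives 50% in a functional assay on Ehrlich cells (Mus musculus) for cytotoxicity, read by trypan blue exclusion, with a stated time of 2 h, tested at 10 ug/mL (a higher number here means a stronger effect of the compound at the concentration tested, a lower number a weaker effect), the higher of the two numbers recorded so far. Within the data shown here, compound 1 `N#CC1=C(NC(N)=O)N(c2ccc(S(N)(=O)=O)cc2)C2=C(C(=O)CCC2)C1c1ccc(Cl)cc1Cl` gives 20% in this assay, and the step of a number 30 percentage points higher from compound 1 to compound 2 (beyond the scatter) is the only measured comparison available. Compound 3 `N#CC1=C(NS(=O)(=O)c2ccc(Br)cc2)N(c2ccc(S(N)(=O)=O)cc2)C2=C(C(=O)CCC2)C1c1ccc(Cl)cc1Cl` has not been measured. It differs from compound 2 by bromo in place of nitro on an aromatic carbon. Among the measured compounds shown here, the one measured step concerns the whole group on the amine nitrogen, (4-nitrophenyl)sulfonyl in place of carbamoyl, and says nothing about an exchange at the aromatic carbon of that sulfonyl ring; no measured pair separates nitro from bromo at that place. With nothing in the data to carry the change, the expectation in this assay is a step no larger than the scatter, in no settled direction, namely an estimated a number 5 percentage points lower from compound 2 to compound 3 (within the scatter). For the measured compounds named here, compound 3 is therefore expected to give about 45%, with a range from 25% to 65%, and the range is left wide because a number 30 percentage points higher from compound 1 to compound 2 (beyond the scatter) is the only step known and it touches a different part of the molecule.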

Compound 3, a percentage reported as activity, at one concentration (the size of the read-out at that concentration, not a potency): 90%
The estimate for compound 3 lay 45 percentage points below the measured number; the measured number lies above the stated range.
By their numbers in this assay, from the lowest: compound 1; then compound 2; then compound 3.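

In this assay the aromatic carbon of the sulfonyl ring proves to be a sensitive position: with the rest of the molecule unchanged, bromo in place of nitro gives a number 40 percentage points higher from compound 2 to compound 3 (beyond the scatter). The earlier comparison could only credit the whole group on the amine nitrogen, whereas the exchange of carbamoyl for (4-bromophenyl)sulfonyl, a number 70 percentage points higher from compound 1 to compound 3 (beyond the scatter), now shows that the outcome of that exchange depends strongly on what the sulfonyl ring carries, and compound 3 stands highest of the three. No available measurement bears on why bromo and nitro differ at this place.

The compounds shown leave open whether the gain belongs to bromo itself or would also appear with another group at this place, such as chloro, methyl, methoxy or an amine, or with a plain phenyl ring carrying no substituent. With a single concentration and a single exposure time, they also leave open whether the stronger effect of compound 3 than of compound 2 at that concentration would hold at other concentrations or times.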